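A Pyridine Swap and Its Expected Effect on Binding

The compounds below may be only part of what the source reports. "The series", "measured", "known", "first", "only" and "open" are said of these compounds alone.

Compound 1 `CS(=O)(=O)Nc1cccc(-c2nc(C(c3ccc(F)cc3)c3ccc(F)cc3)sc2CC(=O)O)c1`: 40 nM
Compound 2 `O=C(O)Cc1sc(C(c2ccc(F)cc2)c2ccc(F)cc2)nc1-c1ccnc(Cl)c1`: 3.1 nM

Among the compounds with values here, in an in vitro assay on HEK385-7 cells for displacement of a labelled ligand from prostaglandin D2 receptor 2 (Homo sapiens) (a higher number here means a weaker inhibitor, a lower number a stronger inhibitor), compound 2 stands lowest of the two numbers, and the one measured step, a 13-fold lower number from compound 1 to compound 2 (1.11 log units; beyond the scatter), is large. Compound 3 `Cc1cc(-c2nc(C(c3ccc(F)cc3)c3ccc(F)cc3)sc2CC(=O)O)cnc1N` differs from compound 2 by 6-amino-5-methylpyridin-3-yl in place of 2-chloropyridin-4-yl on an aromatic carbon. That earlier step concerns the same position but exchanges other groups, so it gives only a loose guide to what the new ring will do. A modest rise in the number is therefore expected, with wide uncertainty: a 3.2-fold higher number from compound 2 to compound 3 (0.51 log units; beyond the scatter). Compound 3 is estimated at 10 nM, within a range from 2.5 nM to 40 nM.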

Compound 3, half-maximal inhibitory concentration: 880 nM
Compound 3: middle estimate off by 88-fold (1.94 log units), on the low side; the measured number lies above the stated range.
By their numbers in this assay, from the lowest: compound 2; then compound 1; then compound 3.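

In this assay the change to 6-amino-5-methylpyridin-3-yl gives a 280-fold higher number from compound 2 to compound 3 (2.45 log units; beyond the scatter) and also a 22-fold higher number from compound 1 to compound 3 (1.34 log units; beyond the scatter) when set against 3-(methanesulfonamido)phenyl. This position on the shared core therefore separates closely sized rings sharply, and a pyridine ring alone does not secure a low number, as compound 2 and compound 3 both carry one. No measurement shown accounts for the loss.

As far as these compounds go, the change alters the attachment point, chlorine, amino and methyl together, so which of these matters stays open. A methoxy group in place of the chlorine of compound 2 would test one part of that question.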